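The source may report more compounds than this note shows. Statements on the series, on what has been measured and on what is new or still open speak of the compounds shown alone.

Among the measured compounds shown here, in a functional assay on SK-BR-3 cells (Homo sapiens) for antiproliferative activity (on this read-out lower numbers stand for stronger inhibition and higher numbers for weaker inhibition), compound 2 `CCCN(CCC)CCCOc1ccc2cc(NC(=O)c3ccc(O)c(CC=C(C)C)c3)c(=O)oc2c1C` reaches only the limit > 50000 nM, and its value is therefore a limit of the assay rather than a number; it is the one compound among the three that sits at the limit of > 50000 nM in this assay, at which 1 of the 3 values shown sits. Compound 1 `CCN(CC)CCCOc1ccc2cc(NC(=O)c3ccc(O)c(CC=C(C)C)c3)c(=O)oc2c1C` gives 4900 nM in this assay, and compound 3 `CC(C)=CCc1cc(C(=O)Nc2cc3ccc(OCCCNCC(=O)O)c(C)c3oc2=O)ccc1O` gives 7570 nM. The move to compound 4 `CC(C)=CCc1cc(C(=O)Nc2cc3ccc(OCCCNCc4ccccc4)c(C)c3oc2=O)ccc1O` is benzylamino in place of dipropylamino on a saturated chain carbon, three bonds along the chain from an oxygen on an aromatic ring. For the measured compounds named here, two measured steps bear on it: an at least 10-fold higher number from compound 1 to compound 2 (1.00 log units; beyond the scatter), and an at least 6.6-fold lower number from compound 2 to compound 3 (0.81 log units; beyond the scatter). Both show the dipropylamino end of the chain as the one that stands out, with the diethylamino and (carboxymethyl)amino ends falling within the scatter of each other. Benzylamino, like (carboxymethyl)amino, carries one hydrogen-bond donor in place of none, so a lower number is expected in this assay. For compound 4 the expected step is an at least 6.2-fold lower number from compound 2 to compound 4 (0.79 log units; beyond the scatter), toward the region of compounds 1 and 3. Compound 4 is estimated at 8000 nM, between 2000 nM and 40000 nM.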

Compound 4, half-maximal inhibitory concentration: 470 nM
Compound 4: the middle estimate sits 17-fold (1.23 log units) above what was measured, outside the stated range (below it).
By their numbers in this assay, from the lowest: compound 4; then compounds 1 and 3 (each within the scatter of the next). At a limit, above all of these: compound 2.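

The earlier compounds shown here showed only that dipropylamino stood apart, whereas in this assay benzylamino gives a 10-fold lower number from compound 1 to compound 4 (1.02 log units; beyond the scatter) and a 16-fold lower number from compound 3 to compound 4 (1.21 log units; beyond the scatter) and so moves beyond the scatter, on the side of stronger inhibition, from the diethylamino and (carboxymethyl)amino ends. Compound 3 and compound 4 carry the same count of hydrogen-bond donors, so that count alone does not separate them, and the widest step shown is an at least 100-fold lower number from compound 2 to compound 4 (2.02 log units; beyond the scatter) at this same place on the chain. Compound 2 stands at a limit of the assay and not at a number: the limit of > 50000 nM in this assay, at which 1 of the 4 values shown sits.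

The compounds shown leave open whether the gain needs the phenyl ring itself, as a cyclohexylmethylamino end would test, or its distance from the nitrogen, as a 2-phenylethylamino end would test. They also leave open how benzylamino behaves on a longer chain.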